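This account rests on a few compounds, and the source may have more. Where it says the series, first, only, none or still open, it means among the compounds named here.

Among the measured compounds shown here, compound 2 `Cc1ccc2[nH]c(C(=O)N[C@H]3CN(S(=O)(=O)c4ccnc(C)c4)C[C@@H]3C(=O)NCCN(C)C)cc2c1` is one of two compounds measured in a functional assay on HEK293 cells for agonist activity at growth hormone secretagogue receptor type 1 (Homo sapiens), read by HTRF and inositol phosphate accumulation, with a stated time of 90 min, in the presence of a further agent that is not named here (a higher number here means a larger maximal response, a lower number a smaller maximal response), and in this assay compound 2 gives 91%. For the measured compounds named here, its only measured neighbour, compound 1 `Cc1ccc2[nH]c(C(=O)N[C@H]3CN(S(=O)(=O)c4ccccc4)C[C@@H]3C(=O)NCCN(C)C)cc2c1`, gives 93% in this assay, so the two values sit within the usual scatter of each other and no order between them can be read.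

The step to compound 3 `Cc1ccc2[nH]c(C(=O)N[C@H]3CN(S(=O)(=O)c4cn(C)nc4C)C[C@@H]3C(=O)NCCN(C)C)cc2c1` changes the group on the sulfonyl sulfur: 1,3-dimethyl-1H-pyrazol-4-yl in place of 2-methylpyridin-4-yl on a sulfonyl sulfur.

Going by the values given here, only one measured step bears on this position. It is the exchange of the aromatic ring on the same sulfonyl sulfur: a number 2 percentage points lower from compound 1 to compound 2 (within the scatter). Since that swap of one aromatic ring for another left the maximal response unmoved beyond the scatter, a second swap of the same kind is expected to do likewise, and the step of a number 1 percentage points lower from compound 2 to compound 3 (within the scatter) is estimated to stay within the scatter. For compound 3 the expected value in this assay is therefore 90%, with a range from 80% to 98%.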

Compound 3, largest response reached (Emax), in percent of the reference or control that the assay uses in the growth hormone secretagogue receptor type 1 assay: 95%
Compound 3: middle estimate off by 5 percentage points, on the low side; low and high end bracket the measured number.
By their numbers in the growth hormone secretagogue receptor type 1 assay, from the lowest: compounds 2, 1 and 3 (each within the scatter of the next).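

In the growth hormone secretagogue receptor type 1 assay, the step to a five-membered aromatic ring on the sulfonyl sulfur stays within the scatter from either six-membered ring: a number 4 percentage points higher from compound 2 to compound 3 (within the scatter), and a number 2 percentage points higher from compound 1 to compound 3 (within the scatter). This position has therefore now accepted three different aromatic rings, including one with two hetero atoms, without a readable change in maximal response. In a physicochemical assay for lipophilicity, measured as octanol-water partition, at pH 7.4 (a lower number here means a more polar compound, a higher number a more lipophilic compound), compound 2 gives 1.7 and compound 3 gives 1.4, which is a number 0.30 log units lower from compound 2 to compound 3 (within the scatter), so this exchange shows no readable change there either. Nothing available offers a cause for these results.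

Going by these compounds, all three compounds carry an aromatic ring on the sulfonyl sulfur, so the effect of a cyclohexyl ring or a short alkyl chain there remains open. So does the effect of an aromatic ring bearing a carboxylic acid.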